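Extending a Methoxy Group to Ethoxy

The source may hold more compounds than are shown below. What is called first, only, known or untested is meant among the compounds shown, and "the series" means these compounds.

Three compounds with a shared core differ only in one group on an aromatic carbon. In a functional assay on SEM cells (Homo sapiens) for inhibition, read by MTT assay, with a stated time of 72 h (on this read-out lower numbers stand for stronger inhibition and higher numbers for weaker inhibition), compound 1 `C=C(Br)C(=O)Nc1cccc(/C=C/C(=O)Nc2ccc(F)cc2)c1` with fluoro gives 8400 nM as its result, compound 2 `C=C(Br)C(=O)Nc1cccc(/C=C/C(=O)Nc2ccc(C)cc2)c1` with methyl gives 190 nM as its result, and compound 3 `C=C(Br)C(=O)Nc1cccc(/C=C/C(=O)Nc2ccc(OC)cc2)c1` with methoxy gives 70 nM as the lowest number of the three. That makes compound 3 the most potent of this small set.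

Compound 4 `C=C(Br)C(=O)Nc1cccc(/C=C/C(=O)Nc2ccc(OCC)cc2)c1` turns methoxy into ethoxy, and the difference is methyl in place of hydrogen on a saturated chain carbon bound to an oxygen on an aromatic ring in a single edit. Put plainly, methyl replaces hydrogen on a saturated chain carbon bound to an oxygen on an aromatic ring. For the measured compounds named here, no measured pair tests such a lengthening directly. The nearest guide is the modest 2.7-fold lower number from compound 2 to compound 3 (0.43 log units; beyond the scatter) for a swap between two small groups. The much larger a 44-fold lower number from compound 1 to compound 2 (1.65 log units; beyond the scatter) and a 120-fold lower number from compound 1 to compound 3 (2.08 log units; beyond the scatter) both start from the fluoro compound and concern a different kind of swap. A small change is therefore expected in this assay with no clear direction, perhaps nothing beyond the scatter. The estimated move is a 1.1-fold higher number from compound 3 to compound 4 (0.06 log units; within the scatter) at the centre of the expectation. For compound 4 the estimate is 80 nM as a middle value, with an expected range from 25 nM to 250 nM for most repeat measurements.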

Compound 4, half-maximal inhibitory concentration: 180 nM
Compound 4: the middle estimate sits 2.3-fold (0.35 log units) below what was measured, and the stated range covers the measured number.
By their numbers in this assay, from the lowest: compound 3; then compounds 4 and 2 (each within the scatter of the next); then compound 1.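

In this assay, this position proves sensitive to a single added methyl on the saturated chain carbon bound to the oxygen: turning methoxy into ethoxy gives a real loss of potency (a 2.6-fold higher number from compound 3 to compound 4 (0.41 log units; beyond the scatter)), which leaves compound 3 as the most potent of the four. Most of the advantage of methoxy over methyl is gone with ethoxy, since the two groups cannot be told apart here (a 1.1-fold lower number from compound 2 to compound 4 (0.02 log units; within the scatter)), yet ethoxy still stands far from fluoro (a 47-fold lower number from compound 1 to compound 4 (1.67 log units; beyond the scatter)), so the large difference from the fluoro compound survives the lengthening. Nothing in the data shown explains why the added methyl has this effect.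

The compounds shown leave open whether a longer chain such as propoxy, or a branched one such as isopropoxy, would continue this loss or level off, and whether a smaller oxygen-bearing group such as hydroxy would match methoxy. On these data alone, whether a chloro or an amino group at the same place would sit nearer to fluoro or to methoxy also remains unknown.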